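This account rests on a few compounds, and the source may have more. Where it says the series, first, only, none or still open, it means among the compounds named here.

Measured in a functional assay on NCI60 cells (Homo sapiens) for antiproliferative activity, read by sulforhodamine B assay, with a stated time of 48 h; on this read-out lower numbers stand for stronger inhibition of growth and higher numbers for weaker inhibition of growth:

- compound 1 `COc1ccc(-c2nsc3c2NC(=O)CC3c2ccc3c(c2)OCCO3)cc1`: 933 nM
- compound 2 `COc1ccc(-c2nsc3c2NC(=O)CC3c2cccc(Cl)c2)cc1`: 1740 nM

Among the compounds with values here, only two numbers exist so far, and they lie within the usual scatter of each other. Compound 2 therefore has compound 1 as its close neighbour, and the two cannot be ranked.

The next compound to be tested is compound 3 `COc1ccc(-c2nsc3c2NC(=O)CC3c2ccc(F)cc2)cc1`. It has 4-fluorophenyl in place of 3-chlorophenyl on a saturated ring carbon of a six-membered non-aromatic ring, and the count of the change is 4-fluorophenyl in place of 3-chlorophenyl on a saturated ring carbon. The swap leaves the rest of compound 2 untouched.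

Within the data shown here, no measured step shows what a single change of this kind does in this assay, so the expectation rests on thin evidence. Among the measured compounds shown here, the only guide is that compound 1, at 933 nM, and compound 2, at 1740 nM, sit within the scatter of each other. No step beyond the scatter is expected, in either direction. The estimated change is a 1.2-fold lower number from compound 2 to compound 3 (0.06 log units; within the scatter).

For compound 3 the expected value is 1500 nM, with an estimated range of 600 nM to 4000 nM.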

Compound 3, concentration for 50% growth inhibition: 3020 nM
For compound 3 the middle estimate is 2.0-fold (0.30 log units) below the measured one; measured number inside the range.
By their numbers in this assay, from the lowest: compounds 1, 2 and 3 (each within the scatter of the next, the first and the last beyond it).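

In this assay, within the data shown here, the first single change at this saturated ring carbon gives a 1.7-fold higher number from compound 2 to compound 3 (0.24 log units; within the scatter), so replacing 3-chlorophenyl with 4-fluorophenyl does not separate compound 2 from compound 3. This swap changes both the halogen and its place on the phenyl ring, yet the two compounds still cannot be ranked. The wider set shows that this carbon is not indifferent to what it carries: compound 1 gives 933 nM and compound 3 gives 3020 nM, and that gap lies beyond the scatter, although compound 2 lies within the scatter of both. No measurement is available that would explain these numbers.

The halogen and its place remain tangled together here, and a pair such as 3-fluorophenyl and 4-fluorophenyl would be needed to read the place of the halogen alone. From the compounds shown here alone, it also remains open how this carbon would respond to a phenyl ring carrying an amine or a carboxylic acid, or to a longer chain in place of the aromatic ring.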